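This account rests on a few compounds, and the source may have more. Where it says the series, first, only, none or still open, it means among the compounds named here.

Measured compounds:
- compound 1 `Fc1ccccc1CSc1nnc(-c2ccncc2)n1-c1ccccc1`: > 50000 nM
- compound 2 `Clc1ccccc1CSc1nnc(-c2ccncc2)n1-c1ccccc1`: 15700 nM
- compound 3 `O=[N+]([O-])c1cccc(CSc2nnc(-c3ccncc3)n2-c2ccccc2)c1`: 22000 nM

In a functional assay on HepG2 cells (Homo sapiens) for inhibition, read by MTT assay, with a stated time of 48 h (a higher number here means a weaker inhibitor, a lower number a stronger inhibitor), compound 1 reaches only > 50000 nM, which is a limit of the assay and not a number. Against it compound 2 stands at 15700 nM, a step of an at least 3.1-fold lower number from compound 1 to compound 2 (0.50 log units; beyond the scatter). Compound 3 sits at 22000 nM, a step of an at least 2.2-fold lower number from compound 1 to compound 3 (0.35 log units; beyond the scatter). Between the two, the step from compound 2 to compound 3 is a 1.4-fold higher number from compound 2 to compound 3 (0.15 log units; within the scatter).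

Compound 4 `O=[N+]([O-])c1ccc(CSc2nnc(-c3ccncc3)n2-c2ccccc2)cc1` is not yet measured in this assay. It differs from compound 1 in one place: 4-nitrophenyl in place of 2-fluorophenyl on a saturated chain carbon bound to a sulfur. For the measured compounds named here, the nearest measured step is the one from compound 1 to compound 3, where a nitrophenyl group also replaced the 2-fluorophenyl group, only with the nitro in another position, and that step was an at least 2.2-fold lower number from compound 1 to compound 3 (0.35 log units; beyond the scatter). Since compound 1 shows only a limit, the true size of that step is not known; it is at least modest. A step of similar kind is therefore expected here, downward in this assay and beyond the scatter, of about an at least 2.5-fold lower number from compound 1 to compound 4 (0.39 log units; beyond the scatter). For compound 4 the expected value in this assay is 20000 nM, within a range from 8000 nM to 50000 nM.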

Compound 4, half-maximal inhibitory concentration: > 50000 nM
Compound 4: a limit, no number (the forecaster's own chance of this, stated with the estimate: 20%); middle value at least 2.5-fold (0.39 log units) from the limit.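

In this assay compound 4 gives > 50000 nM, which is a limit of the assay and not a number. The earlier compounds suggested that a nitrophenyl group in place of 2-fluorophenyl could help, but the nitrophenyl group alone does not settle the outcome at this saturated chain carbon bound to a sulfur: 4-nitrophenyl in place of 3-nitrophenyl gives an at least 2.2-fold higher number from compound 3 to compound 4 (0.35 log units; beyond the scatter), and 4-nitrophenyl in place of 2-chlorophenyl gives an at least 3.1-fold higher number from compound 2 to compound 4 (0.50 log units; beyond the scatter), so among these compounds the placing of the nitro group on the ring matters, with 3-nitrophenyl on the measurable side and 4-nitrophenyl not. The step from compound 1 to compound 4 cannot be read, as both compounds stop at the same limit: the limit of > 50000 nM in this assay, at which 2 of the 4 values shown sit.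

As far as these compounds go, how far compound 1 and compound 4 lie past that limit stays open, so the two cannot be ranked against each other. Also open, from the compounds shown here alone, is what an amine or a carboxylic acid would do on this ring in place of the nitro group, and what a longer chain would do in place of the saturated chain carbon bound to a sulfur.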